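Replacing the difluorophenyl amide cap with dimethoxyphenyl

The source may report more compounds than this note shows. Statements on the series, on what has been measured and on what is new or still open speak of the compounds shown alone.

Compound 1 `COc1cc(C(=O)Nc2ccc(C(=O)/C=C/c3nc(C)c(C)nc3C)cc2)cc(OC)c1OC` gives 4740 nM in a functional assay on MDA-MB-231 cells (Homo sapiens) for antiproliferative activity, read by CCK-8 assay, with a stated time of 72 h; a higher number here means a weaker inhibitor, a lower number a stronger inhibitor.
Compound 2 `Cc1nc(C)c(/C=C/C(=O)c2ccc(NC(=O)c3ccccc3)cc2)nc1C` gives 1840 nM in this assay.
Compound 3 `Cc1nc(C)c(/C=C/C(=O)c2ccc(NC(=O)c3ccc(F)cc3F)cc2)nc1C` gives 1770 nM in this assay.

Compound 3 has the lowest number of the three, but the step of a 1.0-fold lower number from compound 2 to compound 3 (0.02 log units; within the scatter) is within the scatter, so compound 2 and compound 3 cannot be separated; only compound 1 stands clearly apart, with a higher number. Compound 4 `COc1cc(OC)cc(C(=O)Nc2ccc(C(=O)/C=C/c3nc(C)c(C)nc3C)cc2)c1` differs from compound 3 by 3,5-dimethoxyphenyl in place of 2,4-difluorophenyl on a carbonyl carbon. Going by the values given here, no measured step covers this exact change. The step from compound 2 to compound 3 shows that swapping one ring for another on that carbonyl carbon can leave this assay unchanged, whereas compound 1, which carries methoxy groups on the same ring, sits well above compound 3. Compound 4 is therefore expected to give 3000 nM (range 1500 nM to 6500 nM), a step of a 1.7-fold higher number from compound 3 to compound 4 (0.23 log units; within the scatter) towards a weaker inhibitor.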

Compound 4, half-maximal inhibitory concentration: 11600 nM
Beside the measured number, compound 4's estimate is 3.9-fold (0.59 log units) below it; the whole stated range lies below it.
By their numbers in this assay, from the lowest: compounds 3 and 2 (each within the scatter of the next); then compound 1; then compound 4.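

In this assay, the 3,5-dimethoxyphenyl group on the carbonyl carbon raises the number beyond the scatter, with a 6.6-fold higher number from compound 3 to compound 4 (0.82 log units; beyond the scatter) and a 6.3-fold higher number from compound 2 to compound 4 (0.80 log units; beyond the scatter), so this position is not indifferent to its ring, as the step between compound 2 and compound 3 alone might have suggested. Hydrogen in place of methoxy on an aromatic carbon gives a 2.4-fold higher number from compound 1 to compound 4 (0.39 log units; beyond the scatter), so removing a methoxy does not by itself lower the number. Nothing measured here explains these steps.

On these data alone, what remains open is how a single methoxy, or an amine or a carboxylic acid on this ring, would read in this assay.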